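The source may hold more compounds than are shown below. What is called first, only, known or untested is meant among the compounds shown, and "the series" means these compounds.

Measured compounds in a functional assay for inhibition of sodium/hydrogen exchanger (Oryctolagus cuniculus); on this read-out lower numbers stand for stronger inhibition and higher numbers for weaker inhibition:
compound 1 `Cc1cc(-c2ccc(Cl)cc2)c(S(C)(=O)=O)cc1C(=O)N=C(N)N`, 45 nM
compound 2 `Cc1cc(SC(C)C)c(S(C)(=O)=O)cc1C(=O)N=C(N)N`, 12 nM
compound 3 `Cc1cc(Sc2cccc(Cl)c2)c(S(C)(=O)=O)cc1C(=O)N=C(N)N`, 37 nM

Among these three numbers compound 3 stands second highest; its nearest neighbour is compound 1, and the step of a 1.2-fold lower number from compound 1 to compound 3 (0.09 log units; within the scatter) lies within the scatter, while the step of a 3.1-fold higher number from compound 2 to compound 3 (0.49 log units; beyond the scatter) lies beyond it. Compound 4 `Cc1cc(OC2CCCCC2)c(S(C)(=O)=O)cc1C(=O)N=C(N)N` has not yet been measured in this assay. It differs from compound 3 in one place: cyclohexyloxy in place of (3-chlorophenyl)sulfanyl on an aromatic carbon.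

Going by the values given here, two measured steps bear on this change. From compound 1 to compound 2 the number fell, a 3.8-fold lower number from compound 1 to compound 2 (0.57 log units; beyond the scatter), and from compound 2 to compound 3 it rose again, a 3.1-fold higher number from compound 2 to compound 3 (0.49 log units; beyond the scatter); in both, the compound carrying isopropylsulfanyl rather than a chlorophenyl-bearing group gave the lower number. Among the compounds with values here, compound 4 carries cyclohexyloxy, one six-membered non-aromatic ring of carbon only, attached through oxygen; no measured pair changes sulfur to oxygen, so that part of the change is untested. A modest step downward in this assay is therefore expected, a 2.5-fold lower number from compound 3 to compound 4 (0.39 log units; beyond the scatter), of about the size seen toward compound 2. Compound 4 is estimated at 15 nM, within the range 6 nM to 40 nM.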

Compound 4, half-maximal inhibitory concentration: 37 nM
Compound 4: the middle estimate sits 2.5-fold (0.39 log units) below what was measured; low and high end bracket the measured number.
By their numbers in this assay, from the lowest: compound 2; then compounds 3, 4 and 1 (each within the scatter of the next).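

In this assay the exchange of (3-chlorophenyl)sulfanyl for cyclohexyloxy gave no change at the digits printed from compound 3 to compound 4 (within the scatter) at this aromatic carbon, so an aromatic ring and its chlorine are not needed here for a number of this size. The step of a 1.2-fold lower number from compound 1 to compound 4 (0.09 log units; within the scatter) shows the same for the 4-chlorophenyl group, and the three compounds with a six-membered ring at this carbon cannot be told apart. The isopropylsulfanyl group alone stands apart, with a 3.1-fold higher number from compound 2 to compound 4 (0.49 log units; beyond the scatter) in this assay, which shows that removing the aromatic ring is not enough to reach that lower number.

Going by these compounds, whether the sulfur or oxygen link matters stays open, as does how isopropoxy, cyclohexylsulfanyl or an amine at this carbon would read. Nothing measured here accounts for the numbers at this position.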